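The source may hold more compounds than are shown below. What is called first, only, known or untested is meant among the compounds shown, and "the series" means these compounds.

In a physicochemical assay for lipophilicity, read by HPLC, at pH 7.4; on this read-out lower numbers stand for lower lipophilicity and higher numbers for higher lipophilicity:
compound 1 `CCC/N=C1\S/C(=C\c2ccc(O)c(Cl)c2)C(=O)N1C1CCN(C)C(=O)C1`: 0.6
compound 2 `CCC/N=C1\S/C(=C\c2ccc(O)c(C(C)C)c2)C(=O)N1c1ccccc1C`: 4.3
compound 3 `CCC/N=C1\S/C(=C\c2ccc(O)c(C)c2)C(=O)N1c1ccccc1C`: 3.8

Compound 1 has the lowest number of the three, beyond the scatter from both others. Compound 4 `CCC/N=C1\S/C(=C\c2ccc(O)c(Cl)c2)C(=O)N1c1ccccc1OC` differs from compound 1 in one place: 2-methoxyphenyl in place of 1-methyl-2-oxopiperidin-4-yl on an amide-type nitrogen in a ring. This puts 2-methoxyphenyl in place of 1-methyl-2-oxopiperidin-4-yl on an amide-type nitrogen in a ring. Going by the values given here, no measured step covers this exchange. The only one, a number 0.50 log units lower from compound 2 to compound 3 (beyond the scatter), is a methyl in place of isopropyl on an aromatic carbon, so it bears only indirectly. The better guide is compound 3, which also has a six-membered aromatic ring of carbon only at that nitrogen and gives 3.8. A large upward step is therefore expected, estimated as a number 2.90 log units higher from compound 1 to compound 4 (beyond the scatter). Compound 4 is estimated at 3.5, with an expected range from 2.9 to 4.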

Compound 4, distribution coefficient: 3.3
Compound 4: middle estimate off by 0.20 log units, on the high side, and the stated range covers the measured number.
By their numbers in this assay, from the lowest: compound 1; then compound 4; then compound 3; then compound 2.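

In this assay, the change at this position gives a number 2.70 log units higher from compound 1 to compound 4 (beyond the scatter). That is a far larger move than a number 0.50 log units lower from compound 2 to compound 3 (beyond the scatter), so this nitrogen substituent can shift the read-out strongly. The two groups match in heavy atoms, hydrogen-bond donors and hydrogen-bond acceptors, but one has a non-aromatic ring with a hetero atom and the other a six-membered aromatic ring of carbon only. No measurement here accounts for the size of the step. Still open, from the compounds shown here alone, is how this read-out would respond to an amine, a carboxylic acid or a longer chain on this nitrogen.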